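From 2,3-dimethoxyphenyl to 2,3,4-trifluorophenyl on a shared core

The compounds below may be only part of what the source reports. "The series", "measured", "known", "first", "only" and "open" are said of these compounds alone.

Measured in a functional assay on HL-60 cells (Homo sapiens) for antiproliferative activity, with a stated time of 72 h; on this read-out lower numbers stand for stronger inhibition and higher numbers for weaker inhibition:
Compound 1 `OC[C@H]1O[C@@H](n2cnc3c(NCc4ccccc4Cl)ncnc32)[C@H](O)[C@@H]1O`: 1600 nM
Compound 2 `COc1cccc(CNc2ncnc3c2ncn3[C@@H]2O[C@H](CO)[C@@H](O)[C@H]2O)c1`: 4900 nM
Compound 3 `COc1cccc(CNc2ncnc3c2ncn3[C@@H]2O[C@H](CO)[C@@H](O)[C@H]2O)c1OC`: > 166000 nM (a limit, not a number)

Compound 3 has no number in this assay, only (the limit of > 166000 nM in this assay, at which 1 of the 3 values shown sits). Compound 4 `OC[C@H]1O[C@@H](n2cnc3c(NCc4ccc(F)c(F)c4F)ncnc32)[C@H](O)[C@@H]1O` has not yet been measured. It keeps the shared core but carries 2,3,4-trifluorophenyl in place of 2,3-dimethoxyphenyl on a saturated chain carbon bound to a nitrogen on an aromatic ring.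

For the measured compounds named here, three measured steps bear on this change. Placing methoxy on an aromatic carbon in place of hydrogen gave a large step: an at least 33-fold higher number from compound 2 to compound 3 (1.52 log units; beyond the scatter). The swap of 2-chlorophenyl for 2,3-dimethoxyphenyl was also large: an at least 100-fold higher number from compound 1 to compound 3 (2.01 log units; beyond the scatter). The swap of 2-chlorophenyl for 3-methoxyphenyl was much smaller: a 3.1-fold higher number from compound 1 to compound 2 (0.49 log units; beyond the scatter).

Compound 4 has no methoxy on its ring, and neither has compound 1 at 1600 nM. A large step towards a lower number is therefore expected in this assay, though fluorine has not been tested in this set. The expected step is an at least 27-fold lower number from compound 3 to compound 4 (1.44 log units; beyond the scatter). For compound 4 the estimated value is 6000 nM, with an expected range from 1200 nM to 40000 nM.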

Compound 4, half-maximal inhibitory concentration: 13000 nM
The estimate for compound 4 lay 2.2-fold (0.34 log units) below the measured number, within the range that was stated.
By their numbers in this assay, from the lowest: compound 1; then compound 2; then compound 4. At a limit, above all of these: compound 3.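

In this assay, compound 3 has a limit and not a number (the record reads: the limit of > 166000 nM in this assay, at which 1 of the 4 values shown sits). Replacing its 2,3-dimethoxyphenyl with 2,3,4-trifluorophenyl on the same saturated chain carbon gives a measurable number (an at least 12-fold lower number from compound 3 to compound 4 (1.10 log units; beyond the scatter)), so the drop seen with compound 3 is not shared by both rings that carry more than one substituent. Even so, the trifluorinated ring does not match either ring with one substituent, falling short of 3-methoxyphenyl (a 2.7-fold higher number from compound 2 to compound 4 (0.42 log units; beyond the scatter)) and further short of 2-chlorophenyl (an 8.1-fold higher number from compound 1 to compound 4 (0.91 log units; beyond the scatter)).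

The compounds shown leave open whether all three fluorines are needed for this outcome, as no ring here carries just one fluorine. From the compounds shown here alone, how a ring bearing an amine or a carboxylic acid would behave at this position also remains unknown.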